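A few compounds are considered here, and "the series" means these few. Any claim that something is new, unique, unknown or untested is made for them only; others in the source may bear on it.

Measured in a functional assay on A549 cells (Homo sapiens) for antiproliferative activity, read by sulforhodamine B assay, with a stated time of 48 h; a lower number here means a stronger inhibitor, a higher number a weaker inhibitor:
Compound 1 `COc1cc(OC)c2sc(-c3ccc(N/C=C\C(=O)c4cc(OC)c(OC)c(OC)c4)cc3)nc2c1`: 21800 nM
Compound 2 `COc1ccc(C(=O)/C=C\Nc2ccc(-c3nc4cc(OC)c(OC)c(OC)c4s3)cc2)cc1F`: 15500 nM

Compound 2, at 15500 nM, lies within the scatter of compound 1, at 21800 nM, so these two numbers cannot be told apart. For the measured compounds named here, no step between measured compounds that differ in one place is available to size the next change from experiment.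

Compound 3 `COc1cc(C(=O)/C=C\Nc2ccc(-c3nc4cc(OC)c(OC)c(OC)c4s3)cc2)cc(OC)c1OC` keeps the rest of compound 2 and changes on a carbonyl carbon, with 3,4,5-trimethoxyphenyl in place of 3-fluoro-4-methoxyphenyl on a carbonyl carbon. Going by the values given here, with no measured precedent for this swap, no step beyond the scatter is expected in this assay, and no direction is favoured. The estimated change is a 1.0-fold higher number from compound 2 to compound 3 (0.01 log units; within the scatter). For compound 3 the expected value is 16000 nM, with an estimated range of 6000 nM to 40000 nM.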

Compound 3, half-maximal inhibitory concentration: 15500 nM
Compound 3: middle estimate off by 1.0-fold (0.01 log units), on the high side, and the stated range covers the measured number.
By their numbers in this assay, from the lowest: compounds 2, 3 and 1 (each within the scatter of the next).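

In this assay, 3,4,5-trimethoxyphenyl in place of 3-fluoro-4-methoxyphenyl on a carbonyl carbon gives no change at the digits printed from compound 2 to compound 3 (within the scatter), so at this position the entering group, with more heavy atoms and no fluorine, leaves the number unmoved. Methoxy in place of hydrogen on an aromatic carbon gives a 1.4-fold lower number from compound 1 to compound 3 (0.15 log units; within the scatter), so this second one-place change also cannot be told from the scatter. Nothing measured here bears on these results.

On these data alone, neither change shows a step beyond the scatter, so it remains open whether any replacement at either place would move the number in this assay. As far as these compounds go, how an amine or a carboxylic acid in place of the aryl group on the carbonyl carbon would read remains unknown.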